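A few compounds are considered here, and "the series" means these few. Any claim that something is new, unique, unknown or untested is made for them only; others in the source may bear on it.

Three compounds with a shared core were measured in a functional assay on HEK293 cells for agonist activity at growth hormone secretagogue receptor type 1 (Homo sapiens), read by HTRF and inositol phosphate accumulation, with a stated time of 90 min, in the presence of a further agent that is not named here; on this read-out higher numbers stand for larger maximal responses and lower numbers for smaller maximal responses. Compound 1 `O=C(N[C@H]1CN(S(=O)(=O)c2ccccc2)C[C@@H]1C(=O)N[C@H]1CCCNC1)c1cc(-c2ccccc2)on1` gives 90%. Compound 2 `O=C(N[C@H]1CN(S(=O)(=O)c2ccccc2)C[C@@H]1C(=O)N[C@H]1CCCNC1)c1cc(-c2ccc(Cl)cc2)on1` gives 91%, and compound 3 `O=C(N[C@H]1CN(S(=O)(=O)c2ccccc2)C[C@@H]1C(=O)N[C@H]1CCCNC1)c1cc(-c2ccccc2Cl)on1` gives 98%. The number for compound 3 is the highest of the three shown, but a number 8 percentage points higher from compound 1 to compound 3 (within the scatter) and a number 7 percentage points higher from compound 2 to compound 3 (within the scatter) both lie within the scatter, so the three compounds cannot be told apart on this read-out.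

Compound 4 `O=C(N[C@H]1CN(S(=O)(=O)c2ccccc2)C[C@@H]1C(=O)N[C@H]1CCCNC1)c1cc(-c2ccc(Cl)cc2Cl)on1` differs from compound 3 by one change: chloro in place of hydrogen on an aromatic carbon. Among the measured compounds shown here, two measured steps bear on it, each being a chloro in place of hydrogen on an aromatic carbon of the same phenyl group: a number 1 percentage points higher from compound 1 to compound 2 (within the scatter) and a number 8 percentage points higher from compound 1 to compound 3 (within the scatter). Neither reached beyond the scatter. A second chloro on this ring is therefore expected to leave the maximal response essentially where compound 3 stands, with a number 3 percentage points lower from compound 3 to compound 4 (within the scatter) expected to stay within the scatter. Compound 4 is estimated at 95%, within a range from 84% to 104%.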

Compound 4, largest response reached (Emax), in percent of the reference or control that the assay uses: 109%
The estimate for compound 4 lay 14 percentage points below the measured number; the measured number lies above the stated range.
By their numbers in this assay, from the lowest: compounds 1, 2 and 3 (each within the scatter of the next); then compound 4.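

In this assay, the 2,4-dichlorophenyl group of compound 4 gives the first differences in this set that pass the scatter: a number 11 percentage points higher from compound 3 to compound 4 (beyond the scatter), a number 18 percentage points higher from compound 2 to compound 4 (beyond the scatter) and a number 19 percentage points higher from compound 1 to compound 4 (beyond the scatter). A chloro para to the large group thus gives a step beyond the scatter on the 2-chlorophenyl group, but this cannot be set apart from its effect on the unsubstituted phenyl group: the same change on two cores in this assay, a number 1 percentage points higher (within the scatter) from compound 1 to compound 2 and a number 11 percentage points higher (beyond the scatter) from compound 3 to compound 4, 10 percentage points apart, within the scatter of two such steps. The other chloro, added to the 4-chlorophenyl group of compound 2, likewise gives a step that cannot be set apart from the same change on the phenyl group of compound 1: the same change on two cores in this assay, a number 8 percentage points higher (within the scatter) from compound 1 to compound 3 and a number 18 percentage points higher (beyond the scatter) from compound 2 to compound 4, 10 percentage points apart, within the scatter of two such steps.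

On these data alone, what stays open is whether a group other than chloro on this carbon, such as methoxy, trifluoromethyl or an amine, would reach the same maximal response. Also open, as far as these compounds go, is whether the two chloro groups are both required, or whether a single larger group would do as much.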